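Swapping the aryl group on a shared core

The source may hold more compounds than are shown below. What is called first, only, known or untested is meant among the compounds shown, and "the series" means these compounds.

Measured compounds:
Compound 1, `COc1cc(C(C2=C(O)C(=O)c3ccccc3C2=O)c2c[nH]c3ccc(Br)cc23)cc(OC)c1OC`, in a functional assay on ECa-109 cells (Homo sapiens) for cytotoxicity, read by MTT assay, with a stated time of 48 h (a lower number here means a stronger inhibitor, a higher number a weaker inhibitor), compound 1 gives 13000 nM.
Compound 2, `O=C1C(O)=C(C(c2ccccc2)c2c(-c3ccccc3)[nH]c3ccccc23)C(=O)c2ccccc21`, compound 2 gives 5180 nM.
Compound 3, `COc1ccc(C(C2=C(O)C(=O)c3ccccc3C2=O)c2c[nH]c3ccccc23)cc1Br`, compound 3 gives 11800 nM.

Among these three numbers, compound 3 stands second highest. Compound 3 and compound 1 lie within the usual scatter of each other, so no order between them can be read. Compound 2 gives a lower number than compound 3, and that gap lies beyond the scatter.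

Compound 4, `O=C1C(O)=C(C(c2cccc([N+](=O)[O-])c2)c2c[nH]c3ccccc23)C(=O)c2ccccc21`, has not yet been measured in this assay. It differs from compound 3 in one place: 3-nitrophenyl in place of 3-bromo-4-methoxyphenyl on a saturated chain carbon bound to an aromatic carbon and a double-bonded ring carbon. Among the measured compounds shown here, no measured pair here shares exactly this change, so the size of its effect is unknown. The numbers for compound 1 and compound 3 show that two different substituted aryl groups at this position gave values within the scatter of each other, which gives no sign of a large effect. A change within the scatter, or a modest one in either direction, is therefore expected. The expected step is a 1.3-fold lower number from compound 3 to compound 4 (0.12 log units; within the scatter). Compound 4 is estimated at 9000 nM, within a range from 3000 nM to 30000 nM.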

Compound 4, half-maximal inhibitory concentration: 36200 nM
For compound 4 the middle estimate is 4.0-fold (0.60 log units) below the measured one; measured number outside the range, above it.
By their numbers in this assay, from the lowest: compound 2; then compounds 3 and 1 (each within the scatter of the next); then compound 4.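

In this assay, the aryl group on this saturated chain carbon does matter: 3-nitrophenyl in place of 3-bromo-4-methoxyphenyl gives a 3.1-fold higher number from compound 3 to compound 4 (0.49 log units; beyond the scatter), a modest step, but one beyond the scatter. Both groups carry one six-membered aromatic ring of carbon only, so the change lies entirely in what that ring bears. Nothing measured here explains why the number rises.

This single swap removes the bromine and the methoxy group and adds the nitro group all at once, so the compounds shown leave open which of these changes accounts for the step. They also leave open how an amine or a carboxylic acid in place of the nitro group would read in this assay.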